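Exchanging the Ethylpiperazine Ring on Compound 3

A few compounds are considered here, and "the series" means these few. Any claim that something is new, unique, unknown or untested is made for them only; others in the source may bear on it.

The series is followed in a functional assay on Jurkat cells (Homo sapiens) for inhibition, read by CCK-8 assay, with a stated time of 48 h; a lower number here means a stronger inhibitor of growth, a higher number a weaker inhibitor of growth. Compound 1 `CCN1CCN(c2ccc(Nc3ncc(Cl)c(Nc4ccccc4C)n3)nc2)CC1` gives only the limit > 100000 nM there. Compound 2 `Cc1ccccc1Nc1nc(Nc2ccc(N3CCCCC3)cn2)ncc1Cl` likewise gives only the limit > 100000 nM. Going by the values given here, compound 3 `CCN1CCN(c2ccc(Nc3ncc(Cl)c(Nc4ccccc4C)n3)cc2)CC1` gives 2060 nM, the sole number among the three. The change from compound 1 to compound 2 is piperidin-1-yl in place of 4-ethylpiperazin-1-yl on an aromatic carbon, and its step that the two limits leave unreadable from compound 1 to compound 2 cannot be read because of the limit of > 100000 nM in this assay, at which 2 of the 3 values shown sit. How the cores of compound 1 and compound 3 differ is not broken down here.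

Compound 4 `Cc1ccccc1Nc1nc(Nc2ccc(N3CCCCC3)cc2)ncc1Cl` is not yet measured. It differs from compound 3 by piperidin-1-yl in place of 4-ethylpiperazin-1-yl on an aromatic carbon. This is the same kind of change as that from compound 1 to compound 2, though there the place was on an aromatic carbon of a six-membered aromatic ring with 1 nitrogen, two atoms from the ring nitrogen, para to a large group, whereas here the ring is of carbon only. Since the measured step stays unreadable, the expected step of a 2.4-fold higher number from compound 3 to compound 4 (0.39 log units; beyond the scatter) rests only on the number of compound 3, 2060 nM. Compound 4 is estimated at 5000 nM, between 1500 nM and 30000 nM.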

Compound 4, concentration for 50% growth inhibition: > 100000 nM
Compound 4 ended at the assay's limit; the forecaster's own chance of this, stated with the estimate: 12%; middle value at least 20-fold (1.30 log units) away from the limit.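

On the core of compound 3, piperidin-1-yl in place of 4-ethylpiperazin-1-yl gives an at least 48-fold higher number from compound 3 to compound 4 (1.68 log units; beyond the scatter) in this assay, so on this core the exchange is a large loss of growth inhibition. Compound 4 gives a limit rather than a number, so this step marks only how large the loss is at the least, not its actual size. The same exchange on the core of compound 1 cannot be read, so the data neither confirm nor refute that the change carries from one core to the other: the limit of > 100000 nM in this assay, at which 3 of the 4 values shown sit.

The compounds shown leave open whether the loss on the core of compound 3 follows from the missing ring nitrogen or from the missing ethyl group, a question that a piperazin-1-yl with a free amine hydrogen, a 4-methylpiperazin-1-yl or a morpholin-4-yl at that place could help to settle. Also open, from the compounds shown here alone, is whether any such group could bring the core of compound 1 to a readable number in this assay.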